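A few compounds are considered here, and "the series" means these few. Any claim that something is new, unique, unknown or untested is made for them only; others in the source may bear on it.

In an ADME assay on Vero cells (Chlorocebus sabaeus) for cytotoxicity, read by MTT assay, with a stated time of 96 h (on this read-out higher numbers stand for lower toxicity in this test and lower numbers for higher toxicity in this test), compound 1 `CC(=O)c1ccc2c(c1)nc(-c1ccccc1)n2C1CCCCC1` gives 80000 nM. Compound 2 `C/C(=N\NC(N)=O)c1ccc2c(c1)nc(-c1ccccc1)n2C1CCCCC1` gives > 100000 nM, which is a limit and not a number. Compound 3 `C/C(=N\NC(N)=S)c1ccc2c(c1)nc(-c1ccccc1)n2C1CCCCC1` differs from compound 2 in one place: a group of 3 heavy atoms (1 carbon, 1 nitrogen, 1 sulfur; no ring) in place of a group of 3 heavy atoms (1 carbon, 1 nitrogen, 1 oxygen; no ring), on an amine nitrogen, on an amine nitrogen. Among the compounds with values here, the only measured step is an at least 1.2-fold higher number from compound 1 to compound 2 (0.09 log units; that floor lies within the scatter), and it does not touch this exchange of oxygen for sulfur, so it offers weak guidance. Within the data shown here, a modest move toward a lower number is expected in this assay, the only direction a reading could show. The expected change is an at least 1.6-fold lower number from compound 2 to compound 3 (0.22 log units; that floor lies within the scatter). For compound 3 the estimate is 60000 nM, within an expected range of 15000 nM to 100000 nM.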

Compound 3, half-maximal cytotoxic concentration: 20000 nM
For compound 3 the middle estimate is 3.0-fold (0.48 log units) above the measured one; the range from low to high includes it.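

In this assay, sulfur in place of the oxygen of the carbamoyl, on the amine nitrogen, gives an at least 5.0-fold lower number from compound 2 to compound 3 (0.69 log units; beyond the scatter), although the counts of heavy atoms, donors and acceptors stay the same. The sulfur-bearing group on the aromatic carbon also shows a 4.0-fold lower number from compound 1 to compound 3 (0.60 log units; beyond the scatter). Compound 2 stands at a limit and not a number, so the step from it gives only a floor: the limit of > 100000 nM in this assay, at which 1 of the 3 values shown sits.

Left open is whether the lower number belongs to sulfur alone. A group with an imine nitrogen in place of that sulfur is not among the compounds shown.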